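This account rests on a few compounds, and the source may have more. Where it says the series, first, only, none or still open, it means among the compounds named here.

Measured compounds:
- compound 1, `Cc1ccc(S(=O)(=O)c2cnc3c(F)cccc3c2-c2ccc(Cl)cc2)cc1F`: 2.2 mL/min
- compound 2, `N#Cc1cccc(S(=O)(=O)c2cnc3c(F)cccc3c2-c2ccc(Cl)cc2)c1`: 0.08 mL/min

In an ADME assay on microsomes from liver (Homo sapiens) for metabolic stability, tested at 2.5 uM (a lower number here means slower removal, a higher number faster removal of the compound), compound 2 stands lowest of the two numbers; its nearest neighbour is compound 1, and the gap between them is a 28-fold lower number from compound 1 to compound 2 (1.44 log units; beyond the scatter). Compound 3, `O=S(=O)(c1cc(Cl)cc(Cl)c1)c1cnc2c(F)cccc2c1-c1ccc(Cl)cc1`, is not yet measured in this assay. It differs from compound 2 in one place: 3,5-dichlorophenyl in place of 3-cyanophenyl on a sulfonyl sulfur. Going by the values given here, only the step from compound 1 to compound 2 bears on this change, and it was large, so the group on the sulfonyl sulfur clearly matters in this assay. Compound 3 gives up the 3-cyanophenyl that marks the low end, and no second aryl on the sulfonyl sulfur is known here, so the size of the step is uncertain; an upward step is expected, a 10-fold higher number from compound 2 to compound 3 (1.00 log units; beyond the scatter), smaller than the full return to compound 1. For compound 3 the estimate is 0.8 mL/min, within 0.25 mL/min to 2.5 mL/min.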

Compound 3, intrinsic clearance in a liver preparation (reported as CLH), per the amount of preparation that the assay uses: 0.78 mL/min
Compound 3: the middle estimate sits 1.0-fold (0.01 log units) above what was measured; the range from low to high includes it.
By their numbers in this assay, from the lowest: compound 2; then compound 3; then compound 1.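

In this assay, the low number of compound 2 now stands apart from two aryl groups rather than one: 3,5-dichlorophenyl in place of 3-cyanophenyl on the sulfonyl sulfur gives a 9.8-fold higher number from compound 2 to compound 3 (0.99 log units; beyond the scatter). The position also separates two aryl groups without a nitrile, since 3,5-dichlorophenyl in place of 3-fluoro-4-methylphenyl gives a 2.8-fold lower number from compound 1 to compound 3 (0.45 log units; beyond the scatter), so the read-out here does not split simply into nitrile and non-nitrile groups. Nothing available explains this order of the three groups.

With 3-cyanophenyl as the only nitrile-bearing group, the compounds shown cannot separate the contribution of the nitrile from that of the rest of the aryl group. Also open, on these data alone, is where an unsubstituted phenyl, a pyridine ring or a saturated amine such as morpholine on the sulfonyl sulfur would fall in this order.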